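Swapping a Carbamate for a Nitro Group on One Core

The compounds below may be only part of what the source reports. "The series", "measured", "known", "first", "only" and "open" are said of these compounds alone.

Of the compounds shown here, two sharing one core have been tested in an assay on isolated protein for activation of cGMP-dependent protein kinase 1 (Homo sapiens), read by ADP-Glo, with stated times of 30 min and 2 h; on this read-out higher numbers stand for an effect only at larger amounts of compound and lower numbers for an effect already at smaller amounts. Compound 1 `Cc1nc(C(=O)O)ccc1CN1CCC[C@H](O[C@H](CO)c2cc(Cl)cc(Cl)c2)[C@@H]1c1ccccc1` gives 144000 nM in this assay. Compound 2 `COC(=O)Nc1cc(C(=O)O)ccc1CN1CCC[C@H](O[C@H](CO)c2cc(Cl)cc(Cl)c2)[C@@H]1c1ccccc1` gives 69000 nM in this assay, the lowest of the two numbers; compound 1 sits a step above it that lies beyond the usual scatter. Compound 3 `O=C(O)c1ccc(CN2CCC[C@H](O[C@H](CO)c3cc(Cl)cc(Cl)c3)[C@@H]2c2ccccc2)c([N+](=O)[O-])c1` has not yet been measured in this assay. It differs from compound 2 in one place: nitro in place of (methoxycarbonyl)amino on an aromatic carbon. For the measured compounds named here, no pair of measured compounds shows this particular exchange, so there is no measured step to lean on; the two numbers at hand only show that both compounds on this core need large amounts to act. With nothing pointing clearly in either direction, the step is expected to be small and to stay within the scatter, a 1.3-fold higher number from compound 2 to compound 3 (0.12 log units; within the scatter). Compound 3 is therefore estimated to give about 90000 nM in this assay, with a plausible range from 30000 nM to 270000 nM.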

Compound 3, half-maximal effective concentration: 13000 nM
Compound 3: middle estimate off by 6.9-fold (0.84 log units), on the high side; measured number below the stated range.
By their numbers in this assay, from the lowest: compound 3; then compound 2; then compound 1.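

In this assay, nitro in place of (methoxycarbonyl)amino gives a 5.3-fold lower number from compound 2 to compound 3 (0.72 log units; beyond the scatter), so the group on this aromatic carbon, ortho to a large group and meta to a carboxy group, clearly matters, and the hydrogen-bond donor of the (methoxycarbonyl)amino group is not required for activity on this core. For the compounds shown here, exchanging the whole group on the saturated chain carbon bound to the ring amine nitrogen, where a six-membered aromatic ring with one hetero atom gives way to one of carbon only that carries the nitro group, amounts to an 11-fold lower number from compound 1 to compound 3 (1.04 log units; beyond the scatter), which makes this the largest drop seen so far on the shared core. Nothing measured here explains why either number falls.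

The step from compound 1 changes the ring and its substituent together, so the share of each cannot be separated. On these data alone, it also remains open whether a nitrile, an amine or a trifluoromethyl group on the same aromatic carbon would bring the number lower still, or whether the nitro group itself is what counts.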